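The compounds below may be only part of what the source reports. "The series", "measured", "known", "first", "only" and "open" are said of these compounds alone.

Measured so far in a functional assay on SK-BR-3 cells (Homo sapiens) for cytotoxicity, read by MTT assay, with a stated time of 72 h; on this read-out lower numbers stand for stronger inhibition and higher numbers for weaker inhibition:

- compound 1 `Nc1ccc(Nc2c(C(=O)NCc3ccc(F)cc3)nc(Br)c3cccnc23)cc1` gives 4000 nM
- compound 2 `N[C@H]1CC[C@H](Nc2c(C(=O)NCc3ccc(F)cc3)nc(Br)c3cccnc23)CC1` gives 2000 nM
- compound 3 `O=C(NCCCNc1c(C(=O)NCc2ccc(F)cc2)nc(Br)c2cccnc12)c1ccccc1` gives 1000 nM

Compound 2 at 2000 nM and compound 3 at 1000 nM lie within the usual scatter of each other, so the two cannot be ranked. Compound 1 at 4000 nM and compound 3 at 1000 nM are further apart than the scatter, and compound 3 holds the lower number of that pair.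

Compound 4 `NCCCCCCNc1c(C(=O)NCc2ccc(F)cc2)nc(Br)c2cccnc12` has not been measured. It has 3-aminopropyl in place of benzamido on a saturated chain carbon, three bonds along the chain from a nitrogen on an aromatic ring.

Going by the values given here, no measured step removes benzamido, so this change has no direct precedent. Among the compounds with values here, the only step available is a 2.0-fold lower number from compound 1 to compound 2 (0.30 log units; within the scatter) and it exchanges 4-aminophenyl for 4-aminocyclohexyl, which is a different change. It stays within the scatter, so it offers only weak guidance. Compound 2, at 2000 nM and carrying an amino group as compound 4 does, suggests a modest shift at most. In this assay the expected step is a 1.5-fold higher number from compound 3 to compound 4 (0.18 log units; within the scatter) toward a higher number and within the scatter. Compound 4 is estimated at 1500 nM with an expected range of 500 nM to 4000 nM for a single measurement.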

Compound 4, half-maximal inhibitory concentration: 3000 nM
Beside the measured number, compound 4's estimate is 2.0-fold (0.30 log units) below it; the measured number falls inside the stated range.
By their numbers in this assay, from the lowest: compounds 3, 2, 4 and 1 (each within the scatter of the next, the first and the last beyond it).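

In this assay, going by these compounds alone, the step with 3-aminopropyl in place of benzamido, on a saturated chain carbon three bonds along the chain from a nitrogen on an aromatic ring, is a 3.0-fold higher number from compound 3 to compound 4 (0.48 log units; beyond the scatter); this is the first measured change at this place, and it shows that the end of the chain can move the number beyond the scatter. The two other new comparisons, a 1.5-fold higher number from compound 2 to compound 4 (0.18 log units; within the scatter) and a 1.3-fold lower number from compound 1 to compound 4 (0.12 log units; within the scatter), both stay within the scatter, so 6-aminohexyl on that nitrogen cannot be told apart from 4-aminocyclohexyl or from 4-aminophenyl. No accompanying measurement bears on these results, so the numbers alone must stand without an explanation.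

The change removes a six-membered aromatic ring and a carbonyl together, so the compounds shown do not separate the two; an acetamido group at the same place would keep the amide without the ring, and a phenyl group would keep the ring without the amide. A carboxylic acid or a hydroxyl group at the chain end would test whether the terminal amine matters at all.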